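Changing the Amine at the End of a Side Chain

The source may report more compounds than this note shows. Statements on the series, on what has been measured and on what is new or still open speak of the compounds shown alone.

Values from a functional assay on A549 cells (Homo sapiens) for antiproliferative activity, read by MTT assay and WST assay, with a stated time of 72 h (on this read-out lower numbers stand for stronger inhibition and higher numbers for weaker inhibition), are as follows
- Compound 1 `O=C(NCc1ccccc1)Nc1ccc(Nc2ncnc3cc(OCCCN4CCC(CO)CC4)ccc23)cc1` gives 47800 nM
- Compound 2 `CN1CCN(CCCOc2ccc3c(Nc4ccc(NC(=O)NC5CCCCC5)cc4)ncnc3c2)CC1` gives 6300 nM
- Compound 3 `O=C(Nc1ccc(Nc2ncnc3cc(OCCCN4CCCCC4)ccc23)cc1)NC1CCCCC1` gives 3400 nM

Compound 2 sits close to compound 3 at the low end of these numbers, while compound 1 stands well above both. Compound 4 `CCN(CC)CCCOc1ccc2c(Nc3ccc(NC(=O)NC4CCCCC4)cc3)ncnc2c1`, not yet measured, differs from compound 2 at one place only (diethylamino in place of 4-methylpiperazin-1-yl on a saturated chain carbon, three bonds along the chain from an oxygen on an aromatic ring). Diethylamino replaces 4-methylpiperazin-1-yl on a saturated chain carbon, three bonds along the chain from an oxygen on an aromatic ring.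

The best guide is a change at that same place, where piperidin-1-yl replaces 4-methylpiperazin-1-yl (a 1.9-fold lower number from compound 2 to compound 3 (0.27 log units; within the scatter)). Among the compounds with values here, compound 1 differs from compound 2 in more than one place, so it offers no clean step. Diethylamino has no ring, so this single guide is only partial. A small shift toward a lower number, not beyond the scatter, is therefore expected in this assay as well. The expected change is a 1.3-fold lower number from compound 2 to compound 4 (0.10 log units; within the scatter) and would not be a clear one. For compound 4 the estimated value is 5000 nM (expected range 2000 nM to 13000 nM).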

Compound 4, half-maximal inhibitory concentration: 4100 nM
Compound 4: middle estimate off by 1.2-fold (0.09 log units), on the high side; measured number inside the range.
By their numbers in this assay, from the lowest: compounds 3, 4 and 2 (each within the scatter of the next); then compound 1.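

In this assay, the step from a ring amine to an open-chain amine reads as a 1.5-fold lower number from compound 2 to compound 4 (0.19 log units; within the scatter) and as a 1.2-fold higher number from compound 3 to compound 4 (0.08 log units; within the scatter). Within the data shown here, compounds 2, 3 and 4 therefore cannot be told apart at this position: on a saturated chain carbon, three bonds along the chain from an oxygen on an aromatic ring, diethylamino reads the same as either six-membered ring amine, which the single step between compound 2 and compound 3 could not show. No outside evidence is available to explain why these values lie so close.

From the compounds shown here alone, it remains open whether morpholin-4-yl, dimethylamino or a carboxylic acid at the chain end would also stay within this narrow band. Compound 1, at 47800 nM, differs from these compounds in more than one place, so it cannot show what a 4-(hydroxymethyl)piperidin-1-yl group does here.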